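A few compounds are considered here, and "the series" means these few. Any claim that something is new, unique, unknown or untested is made for them only; others in the source may bear on it.

Measured compounds in a functional assay on CHO cells for agonist activity at adenosine receptor A1 (Homo sapiens), read by fluorescence and ERK phosphorylation, with stated times of 30 min and 1.5 h, tested at 10 uM; a lower number here means a weaker effect, a higher number a stronger effect of the compound at the concentration tested:
- Compound 1, `Nc1scc(-c2cccc(Cl)c2)c1C(=O)c1ccccc1`: 52%
- Compound 2, `Nc1scc(-c2cccc([N+](=O)[O-])c2)c1C(=O)c1ccccc1`: 50%

Both compounds share the same core and differ only in one group on the outer six-membered ring. For the measured compounds named here, the one measured step between them, a number 2 percentage points lower from compound 1 to compound 2 (within the scatter), is nitro in place of chloro on an aromatic carbon. On the two numbers shown, compound 2 sits alongside compound 1; the two values differ only within the scatter, so neither can be said to act more strongly than the other in this assay.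

Compound 3, `COc1cccc(-c2csc(N)c2C(=O)c2ccccc2)c1`, is the next compound in the same series. Its change from compound 2 is methoxy in place of nitro on an aromatic carbon. Going by the values given here, the only measured step that touches the same spot is a number 2 percentage points lower from compound 1 to compound 2 (within the scatter), and that exchange moved the number hardly at all. With a single step to go by, and that step within the scatter, there is no sign yet that this position on the ring drives the read-out. The expected step of a number 2 percentage points lower from compound 2 to compound 3 (within the scatter) is therefore no more than the scatter. Compound 3 is estimated to give 48% in this assay, with a range from 30% to 65%.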

Compound 3, a percentage reported as activity, at one concentration (the size of the read-out at that concentration, not a potency): 34%
Compound 3: middle estimate off by 14 percentage points, on the high side; the measured number falls inside the stated range.
By their numbers in this assay, from the lowest: compound 3; then compounds 2 and 1 (each within the scatter of the next).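

In this assay, the position on the outer ring proves sensitive to the group it carries: methoxy in place of nitro gives a number 16 percentage points lower from compound 2 to compound 3 (beyond the scatter), and methoxy in place of chloro gives a number 18 percentage points lower from compound 1 to compound 3 (beyond the scatter). The earlier exchange of chloro for nitro left the two values within the scatter of each other, whereas methoxy is the first group shown to separate itself from the others at this spot, and it does so in the downward direction. No measurement is available to explain why methoxy behaves differently from chloro and nitro.

The three compounds cannot show whether the lower number depends on the oxygen link itself or on the methyl attached to it, and a hydroxyl group or a longer ethoxy chain at the same spot would help separate those two possibilities. An amine or a carboxylic acid there would show how widely the number can move, while the same read-out at a range of concentrations would show whether the weaker effect seen at one concentration also holds at others.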